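The compounds below may be only part of what the source reports. "The series", "measured", "known", "first", "only" and "open" are said of these compounds alone.

Measured so far in a functional assay on MCF7 cells (Homo sapiens) for cytotoxicity, read by sulforhodamine B assay, with a stated time of 48 h; a higher number here means a weaker inhibitor of growth, a lower number a stronger inhibitor of growth:
compound 1, `NC(=S)N/N=C1/C(=O)N(CN2CCN(c3ccnc4cc(Cl)ccc34)CC2)c2cc(Cl)ccc21`, giving 22500 nM;
compound 2, `NC(=S)N/N=C1/C(=O)N(CN2CCN(c3ccnc4cc(C(F)(F)F)ccc34)CC2)c2cccc(Br)c21`, giving 50600 nM;
compound 3, `NC(=S)N/N=C1/C(=O)N(CN2CCN(c3ccnc4cc(C(F)(F)F)ccc34)CC2)c2cc(Cl)ccc21`, giving 24600 nM.

Compound 3 sits second highest of the three numbers in this assay. Its nearest neighbour is compound 1, which differs only by the step of a 1.1-fold higher number from compound 1 to compound 3 (0.04 log units; within the scatter), so these two compounds cannot be told apart on the evidence. Among the measured compounds shown here, compound 2 lies furthest away, and its value in this assay is beyond the scatter from that of compound 3, though the two structures differ in more than one place, so no single step can be drawn between them.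

Compound 4, `NC(=S)N/N=C1/C(=O)N(CN2CCN(c3ccnc4cc(C(F)(F)F)ccc34)CC2)c2ccccc21`, has not yet been measured. It differs from compound 3 by hydrogen in place of chloro on an aromatic carbon. For the measured compounds named here, none of the measured steps touches this position: the only step available concerns the other ring system, and it stayed within the scatter. There is therefore no direct guide to what losing the chloro should do in this assay. With nothing pointing either way, the expected step of a 1.1-fold higher number from compound 3 to compound 4 (0.06 log units; within the scatter) is small, within the scatter, in no particular direction. Compound 4 is accordingly estimated at 28000 nM in this assay, with a range from 12000 nM to 70000 nM.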

Compound 4, concentration for 50% growth inhibition: 13900 nM
Beside the measured number, compound 4's estimate is 2.0-fold (0.30 log units) above it; the measured number falls inside the stated range.
By their numbers in this assay, from the lowest: compounds 4, 1 and 3 (each within the scatter of the next); then compound 2.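

In this assay, among the compounds shown here, the step of a 1.8-fold lower number from compound 3 to compound 4 (0.25 log units; within the scatter) gives the first reading at this aromatic carbon: with chloro gone and hydrogen in its place, the result cannot be told apart from that of compound 3. The halogen in compound 3 therefore shows no measurable contribution to growth inhibition in this pair. The step of a 3.6-fold lower number from compound 2 to compound 4 (0.56 log units; beyond the scatter) is modest but does clear the scatter, so the bromo compound stands apart from its counterpart bearing hydrogen, though compound 2 and compound 3 differ in more than one place and the two steps do not compare bromo with chloro on one carbon. Nothing available here accounts for either step.

The compounds shown leave open whether fluoro, methoxy or an amine on this aromatic carbon would shift the number beyond the scatter, and whether bromo on the carbon that holds the chloro of compound 3 would match the result of compound 2. They also leave open whether hydrogen in place of chloro would give a similar step with the chloro-bearing second ring system of compound 1.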